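The compounds below may be only part of what the source reports. "The series", "measured", "known", "first", "only" and "open" are said of these compounds alone.

Compound 2 `C[C@@H]1O[C@@]1(C)C(=O)C[C@@H]1[C@@]2(C)[C@@H](O)CCC(C)(C)[C@]2(O)CC[C@@]1(C)O` and compound 1 `C[C@H]1O[C@]1(C)C(=O)C[C@@H]1[C@@]2(C)[C@@H](O)CCC(C)(C)[C@]2(O)CC[C@@]1(C)O` share one core and differ only in configuration as drawn (the fact that compounds 1 and 2 differ only in the configuration as drawn). In a functional assay on A2780 cells (Homo sapiens) for cytotoxicity, read by MTT assay, with a stated time of 24 h (on this read-out higher numbers stand for weaker inhibition and lower numbers for stronger inhibition), compound 1 gives only a limit, > 10000 nM. In this assay compound 2 also gives only a limit, > 10000 nM. Both values sit at the limit of > 10000 nM in this assay, at which 2 of the 2 values shown sit, so the step that the two limits leave unreadable from compound 1 to compound 2 cannot be read. Compound 3 `C/C=C(\C)C(=O)C[C@@H]1[C@@]2(C)[C@@H](O)CCC(C)(C)[C@]2(O)CC[C@@]1(C)O` carries 1-methylprop-1-en-1-yl in place of 2,3-dimethyloxiran-2-yl on a carbonyl carbon. No measured step touches this exchange, and the single step shown is unreadable, so nothing beyond the limit of compound 2 guides the expectation. Compound 3 is therefore expected at 20000 nM, within 4000 nM to 100000 nM. This amounts to an expected step that the limit leaves unreadable from compound 2 to compound 3.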

Compound 3, half-maximal inhibitory concentration: > 10000 nM
Compound 3: only a limit was reported (the forecaster's own chance of this, stated with the estimate: 70%); the middle value lies beyond the limit too.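

In this assay compound 3 gives > 10000 nM and this is only a limit, so its steps from compound 1 and compound 2 cannot be read. The compounds shown leave open whether configuration or the exchange of 2,3-dimethyloxiran-2-yl for 1-methylprop-1-en-1-yl changes cytotoxicity at all.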